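A few compounds are considered here, and "the series" means these few. Any claim that something is new, unique, unknown or untested is made for them only; others in the source may bear on it.

Measured compounds:
compound 1, `Nc1cc(N)c2nc(-c3ccccc3)c(Oc3ccc(Cl)c(Cl)c3)nc2c1`: 66100 nM
compound 2, `CCOC(=O)[C@H](CCC(=O)O)NC(=O)c1ccc(CNc2nc3cc(N)cc(N)c3nc2-c2ccccc2)cc1`: < 100000 nM

Within the data shown here, in a functional assay on SK-OV-3 cells (Homo sapiens) for inhibition, read by sulforhodamine B assay, with a stated time of 48 h (on this read-out lower numbers stand for stronger inhibition of growth and higher numbers for weaker inhibition of growth), compound 1 gives 66100 nM, and this is the only number in hand for the series. Compound 2 is reported in this assay only as a limit, < 100000 nM, not as a number. The remaining evidence on the series is the limit of < 100000 nM in this assay, at which 1 of the 2 values shown sits.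

Compound 3 `Nc1cc(N)c2nc(-c3ccccc3)c(Sc3ccc(F)cc3)nc2c1` is not yet measured in this assay. It differs from compound 1 by (4-fluorophenyl)sulfanyl in place of 3,4-dichlorophenoxy on an aromatic carbon. Among the measured compounds shown here, no step between two measured compounds is available to calibrate this change, so the expectation for compound 3 rests on compound 1 alone. The step from compound 1 to compound 3 is expected to be a 1.2-fold lower number from compound 1 to compound 3 (0.08 log units; within the scatter), a shift not beyond the scatter in either direction. Compound 3 is therefore estimated at 55000 nM, with a range from 15000 nM to 150000 nM in this assay.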

Compound 3, concentration for total growth inhibition: 31600 nM
The estimate for compound 3 lay 1.7-fold (0.24 log units) above the measured number, and the stated range covers the measured number.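

In this assay, the aromatic carbon next to the ring nitrogen now has its first readable step: (4-fluorophenyl)sulfanyl in place of 3,4-dichlorophenoxy gives a 2.1-fold lower number from compound 1 to compound 3 (0.32 log units; beyond the scatter) on the shared core. This shows that the substituent at this carbon can be exchanged with a modest change in the number, while a six-membered aromatic ring of carbon is kept in both groups. The exchange alters the linking atom and the ring halogens together, so this single step cannot assign the change to either one. No measured property in hand bears on this step.

Going by these compounds, the separate contributions of the sulfur link, the fluorine and the two chlorines remain open, as a single pair cannot divide them. Also open, on these data alone, is how this position responds to a group without an aromatic ring, such as a morpholine or a short alkoxy chain.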